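Acetyl to dimethylamino on the pendant phenyl ring

The source may hold more compounds than are shown below. What is called first, only, known or untested is meant among the compounds shown, and "the series" means these compounds.

Compound 1 `COc1cc(C)cc(-c2c(-c3ccnc(-c4ccc(C(C)=O)cc4)c3)cnn2CC#N)c1` and compound 2 `COc1cc(C)cc(-c2nn(CC#N)cc2-c2ccc(-c3cccc(C(C)=O)c3)nc2)c1` share a core and differ in how the acetylphenyl group is attached to the pyridine ring. In a functional assay on KM12 cells (Homo sapiens) for cytotoxicity, read by sulforhodamine B assay, with a stated time of 48 h, tested at 0.01 uM (on this read-out higher numbers stand for a weaker effect at the one concentration tested and lower numbers for a stronger effect), compound 1 gives 97% and compound 2 gives 96%; the two numbers are within the scatter of each other, so neither can be called the stronger. Compound 1 stands as the higher of the two numbers, by a margin that means nothing. Compound 3 `COc1cc(C)cc(-c2c(-c3ccnc(-c4ccc(N(C)C)cc4)c3)cnn2CC#N)c1` carries the change dimethylamino in place of acetyl on an aromatic carbon relative to compound 1. Among the compounds with values here, no measured pair shows the effect of such a change, and both measured numbers sit close to the top of the scale, which leaves little room for a weaker effect. The step of a number 2 percentage points lower from compound 1 to compound 3 (within the scatter) is expected to be small and within the scatter, with no direction claimed. Compound 3 is therefore estimated at 95%, with a range from 82% to 104%.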

Compound 3, a percentage reported as activity, at one concentration (the size of the read-out at that concentration, not a potency): 20%
Beside the measured number, compound 3's estimate is 75 percentage points above it; the whole stated range lies above it.
By their numbers in this assay, from the lowest: compound 3; then compounds 2 and 1 (each within the scatter of the next).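

The group on this aromatic carbon, para to a large group, strongly affects the read-out in this assay: a number 77 percentage points lower from compound 1 to compound 3 (beyond the scatter), whereas the earlier pair, which differs in how the acetylphenyl group is attached, showed no separation. Acetyl and dimethylamino match in heavy-atom count, hydrogen-bond donors, hydrogen-bond acceptors and net charge, so these counts do not distinguish the two groups, even though the exchange of 4-acetylphenyl for 4-(dimethylamino)phenyl gives a large step. No evidence is available to explain the size of this step.

As far as these compounds go, it remains open whether the effect is specific to dimethylamino or extends to other amines, such as a primary amine or morpholine, at this place. From the compounds shown here alone, it is also open whether the same step would appear with the attachment found in compound 2.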